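Compound 1 to compound 4: hydrogen replaces methyl

A few compounds are considered here, and "the series" means these few. Any claim that something is new, unique, unknown or untested is made for them only; others in the source may bear on it.

Measured values in an in vivo ADME assay on the whole organism (strain Sprague-Dawley) for pharmacokinetics, with Rattus norvegicus as the target (on this read-out higher numbers stand for wider distribution into tissues and lower numbers for narrower distribution), are these.
Compound 1 `Cc1cc(C(C)CC(=O)O)ccc1-c1noc(-c2ccc(OC(C)C)c(C(F)(F)F)c2)n1` gives 0.6 L/kg
Compound 2 `Cc1nc(CCC(=O)O)ccc1-c1noc(-c2ccc(OC(C)C)c(C#N)c2)n1` gives 0.3 L/kg
Compound 3 `Cc1cc([C@@H]2C[C@H]2C(=O)O)ccc1-c1noc(-c2ccc(OC(C)C)c(C#N)c2)n1` gives "not determined" (no result reported); 1 L/kg; 0.4 L/kg (3 entries)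

For the measured compounds named here, compound 1 stands within the usual scatter of compound 2, the only other compound with a single number. Single readings also vary, as the several entries of compound 3 in this assay, "not determined" (no result reported); 1 L/kg; 0.4 L/kg (3 entries) show. Compound 4 `Cc1cc(CCC(=O)O)ccc1-c1noc(-c2ccc(OC(C)C)c(C(F)(F)F)c2)n1` has not been measured. It differs from compound 1 by hydrogen in place of methyl on a saturated chain carbon bound to an aromatic carbon and a saturated chain carbon, which turns 1-(carboxymethyl)ethyl into 2-carboxyethyl. Going by the values given here, no measured step shows the size of this change, so the estimate starts from compound 1 at 0.6 L/kg and assumes little movement. The expected 1.2-fold lower number from compound 1 to compound 4 (0.08 log units; within the scatter) stays within the scatter of this assay in either direction. Compound 4 is expected at 0.5 L/kg with an estimated range from 0.25 L/kg to 1 L/kg in this read-out.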

Compound 4, volume of distribution at steady state: 1.1 L/kg
Estimate against measurement, compound 4: 2.2-fold (0.34 log units) below; the whole stated range lies below it.
By their numbers in this assay, from the lowest: compounds 2, 1 and 4 (each within the scatter of the next, the first and the last beyond it).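

Hydrogen in place of methyl at this saturated chain carbon, which turns 1-(carboxymethyl)ethyl into 2-carboxyethyl, gives the only measured step at this position in this assay, and it reads a 1.8-fold higher number from compound 1 to compound 4 (0.26 log units; within the scatter). The methyl can thus go without a shift that this read-out can separate from the scatter. Single readings spread at least as far: the several entries of compound 3 in this assay, "not determined" (no result reported); 1 L/kg; 0.4 L/kg (3 entries)

Going by these compounds, whether an ethyl or a hydroxyl at this carbon would move the number beyond the scatter remains open. So does the effect of this same change on the other compounds' cores.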